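Amine substituent swap on the shared core

The source may hold more compounds than are shown below. What is called first, only, known or untested is meant among the compounds shown, and "the series" means these compounds.

Measured compounds:
compound 1 `CC(C)NCc1cn(CC(=O)Nc2sc3c(c2C(N)=O)CCCC3)nc1C(F)(F)F`: 3160 nM
compound 2 `CC(C)NCc1cn(CC(=O)Nc2sc3c(c2C(N)=O)CCCC3)nc1C(C)(C)C`: 1580 nM
compound 3 `O=C(Cn1nc(C(F)(F)F)c2c1CCCC2)Nc1sc2c(c1C(=O)N[C@@H]1CCNC1)CCCC2`: 251 nM

In an assay on isolated protein with metabotropic glutamate receptor 1 (Homo sapiens) as the target (a higher number here means that more compound is needed for the effect, a lower number that less compound is needed), compound 1 stands highest of the three numbers; compound 2 sits within the scatter of it, while compound 3 gives a clearly lower number. Compound 4 `COCCNCc1cn(CC(=O)Nc2sc3c(c2C(N)=O)CCCC3)nc1C(F)(F)F` differs from compound 1 by 2-methoxyethyl in place of isopropyl on an amine nitrogen. Among the compounds with values here, the only measured single-place step, a 2.0-fold lower number from compound 1 to compound 2 (0.30 log units; within the scatter), changes a group on an aromatic carbon and lies within the scatter. Within the data shown here, compound 3 differs from compound 1 in several places at once, so no measured step bears on the amine substituent itself. Without such a precedent, no step beyond the scatter is expected in this assay. Compound 4 is therefore estimated at 3000 nM, with a range of 1000 nM to 10000 nM. The expected step is a 1.1-fold lower number from compound 1 to compound 4 (0.02 log units; within the scatter).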

Compound 4, half-maximal effective concentration: 1580 nM
The estimate for compound 4 lay 1.9-fold (0.28 log units) above the measured number; low and high end bracket the measured number.
By their numbers in this assay, from the lowest: compound 3; then compounds 2, 4 and 1 (each within the scatter of the next).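

In this assay, the amine nitrogen now has its first measured step, 2-methoxyethyl in place of isopropyl (a 2.0-fold lower number from compound 1 to compound 4 (0.30 log units; within the scatter)). The entering group brings oxygen and a hydrogen-bond acceptor, yet the step stays within the scatter, so this assay does not separate the two substituents. No available evidence bears on this result.

Still open, from the compounds shown here alone, is how a carboxylic acid, a ring or a longer chain on this amine nitrogen would read in this assay. Going by these compounds, whether the step holds with tert-butyl in place of trifluoromethyl also remains open.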